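Swapping an amide substituent for an acyl hydrazide linker

This account rests on a few compounds, and the source may have more. Where it says the series, first, only, none or still open, it means among the compounds named here.

Measured compounds:
- Compound 1, `COc1ccc2nc(C)cc(OCC(=O)Nc3ccc(Br)c(C)c3)c2c1`: 5.95
- Compound 2, `COc1ccc2nc(C)cc(OCC(=O)Nc3c(C)cncc3C)c2c1`: 3.01

In a physicochemical assay for lipophilicity, read by HPLC, in phosphate buffer, measured as chromatographic lipophilicity, at pH 7.4 (on this read-out higher numbers stand for higher lipophilicity and lower numbers for lower lipophilicity), compound 2 gives 3.01, the lower of the two numbers measured; compound 1 gives 5.95. Among the compounds with values here, the only measured step, a number 2.94 log units lower from compound 1 to compound 2 (beyond the scatter), shows how strongly the group on the amide-type nitrogen shapes the read-out.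

Compound 3, `COc1ccc2nc(C)cc(OCC(=O)NNC(=O)c3ccncc3)c2c1`, has not yet been measured. It differs from compound 2 in one place: ((pyridin-4-yl)carbonyl)amino in place of 3,5-dimethylpyridin-4-yl on an amide-type nitrogen. The two methyl groups leave, and a carbonyl together with an amide hydrogen enters between the amide-type nitrogen and the pyridine ring.

Within the data shown here, no measured pair shows exactly this change. The step from compound 1 to compound 2 bears on it only in showing that changes at this position reach far beyond the scatter. Compound 3 is expected to fall below compound 2 in this assay, with an estimated step of a number 1.31 log units lower from compound 2 to compound 3 (beyond the scatter). Compound 3 is thus estimated at 1.7, within a range of 0.9 to 2.5.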

Compound 3, distribution coefficient: 1.48
Estimate against measurement, compound 3: 0.22 log units above; measured number inside the range.
By their numbers in this assay, from the lowest: compound 3; then compound 2; then compound 1.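

In this assay, the acyl hydrazide group goes further than the 3,5-dimethylpyridin-4-yl group did, with a number 1.53 log units lower from compound 2 to compound 3 (beyond the scatter), so the number at this position had not reached its floor with compound 2. Set against the 4-bromo-3-methylphenyl group, the same ((pyridin-4-yl)carbonyl)amino group gives a number 4.47 log units lower from compound 1 to compound 3 (beyond the scatter), the widest step among these compounds, and shows how far a change at this one place can move the read-out while the rest of the molecule stays the same. No measurement available here explains why the number falls this far.

The two methyl groups leave as the carbonyl and the amide hydrogen enter, so these compounds cannot separate the share of each in the step. From the compounds shown here alone, whether a simple amine or a carboxylic acid on the amide-type nitrogen would give a number lower still remains open.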